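Moving the Chlorine: From Compound 2 to Compound 3

The compounds below may be only part of what the source reports. "The series", "measured", "known", "first", "only" and "open" are said of these compounds alone.

Compound 1 `COc1ccc(C(=O)/C=C/c2cccc(C(F)(F)F)c2)c2c1C=CC(C)(C)O2` gives 7870 nM
Compound 2 `COc1ccc(C(=O)/C=C/c2ccc(Cl)cc2)c2c1C=CC(C)(C)O2` gives > 10000 nM

In a functional assay on SW-620 cells (Homo sapiens) for antiproliferative activity, read by MTT assay, with a stated time of 24 h (a higher number here means a weaker inhibitor, a lower number a stronger inhibitor), compound 1 gives 7870 nM as a true number. Compound 2 gives > 10000 nM as a limit of the assay and not a number. Compound 2 thus stands at the limit of > 10000 nM in this assay, at which 1 of the 2 values shown sits, and has no number of its own.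

Compound 3 `COc1ccc(C(=O)/C=C/c2cccc(Cl)c2)c2c1C=CC(C)(C)O2` has not yet been measured. It carries 3-chlorophenyl in place of 4-chlorophenyl on a double-bonded chain carbon bound to a double-bonded chain carbon and keeps the rest of compound 2 unchanged.

For the measured compounds named here, no two measured compounds differ in one place only, so no measured step can serve as a guide. In this assay a small step is expected, towards a lower number if there is any change, and it may not go beyond the usual scatter. Going by the values given here, this expectation leans on compound 1 (value 7870 nM), the only reading with a number so far. Compound 3 may also turn out to be reported only as a limit.

The estimated change is an at least 1.1-fold lower number from compound 2 to compound 3 (0.04 log units; that floor lies within the scatter) and remains an expectation. Compound 3 is estimated at 9000 nM (expected range 4000 nM to 20000 nM).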

Compound 3, half-maximal inhibitory concentration: > 10000 nM
Compound 3: only a limit was reported (the forecaster's own chance of this, stated with the estimate: 50%); middle value at least 1.1-fold (0.04 log units) away from the limit.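

In this assay compound 3 gives > 10000 nM, which is a limit of the assay and not a number. Putting 3-chlorophenyl in place of 4-chlorophenyl therefore gives a step that cannot be read, because compound 2 and compound 3 both rest at the same limit, so any difference between them is hidden: the limit of > 10000 nM in this assay, at which 2 of the 3 values shown sit. The comparison that can be read is chloro in place of trifluoromethyl on an aromatic carbon, which gives an at least 1.2-fold higher number from compound 1 to compound 3 (0.10 log units; that floor lies within the scatter); only the smallest possible size of this step is known, and since that floor lies within the usual scatter, the change is not shown to be a real one, though the true step could be larger.

On these data alone, how far compound 2 and compound 3 lie past the limit, and so whether the place of the chlorine matters at all, stays open. For the compounds shown here, also open is whether an amine or a carboxylic acid in place of the chlorine would bring the number clearly down from the level of compound 1, the only compound here with a true number.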